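Swapping chloro for chloromethyl on the shared core

This account rests on a few compounds, and the source may have more. Where it says the series, first, only, none or still open, it means among the compounds named here.

Compound 3 `O=c1cc(Cl)c2ccc(OCc3cccc(Cl)c3)cc2o1` gives the lowest of the three numbers in an assay on isolated protein (strain Sprague-Dawley) for inhibition of Amine oxidase [flavin-containing] B (Rattus norvegicus), read by spectrophotometry, with a stated time of 5 min (on this read-out higher numbers stand for weaker inhibition and lower numbers for stronger inhibition), at 20.9 nM. Compound 2 `CNC(=O)COc1cc(=O)oc2cc(OCc3cccc(Cl)c3)ccc12` sits within the scatter of it at 33.9 nM, while compound 1 `CCOc1cc(=O)oc2cc(OCc3cccc(Cl)c3)ccc12` lies further off at 115 nM. Compound 4 `O=c1cc(CCl)c2ccc(OCc3cccc(Cl)c3)cc2o1` differs from compound 3 in one place: chloromethyl in place of chloro on an aromatic carbon. Among the compounds with values here, no measured step exchanges these two groups, so nothing bears on it directly. The two steps that touch the same aromatic carbon, a 5.5-fold lower number from compound 1 to compound 3 (0.74 log units; beyond the scatter) and a 1.6-fold lower number from compound 2 to compound 3 (0.21 log units; within the scatter), were modest or within the scatter, so a change of similar or smaller size is expected here, in no firm direction. Compound 4 is therefore estimated at 28 nM, between 9 nM and 90 nM, an expected step of a 1.3-fold higher number from compound 3 to compound 4 (0.13 log units; within the scatter).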

Compound 4, half-maximal inhibitory concentration: 43.7 nM
The estimate for compound 4 lay 1.6-fold (0.19 log units) below the measured number; the range from low to high includes it.
By their numbers in this assay, from the lowest: compounds 3, 2 and 4 (each within the scatter of the next, the first and the last beyond it); then compound 1.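

The direct exchange on the aromatic carbon opposite the ring oxygen gives a 2.1-fold higher number from compound 3 to compound 4 (0.32 log units; beyond the scatter) and shows that chloro and chloromethyl are not interchangeable there, although the step is modest. Replacing ethoxy with chloromethyl gives a 2.6-fold lower number from compound 1 to compound 4 (0.42 log units; beyond the scatter) as a gain, whereas replacing (methylcarbamoyl)methoxy with chloromethyl gives a 1.3-fold higher number from compound 2 to compound 4 (0.11 log units; within the scatter) and leaves those two groups unseparated. Nothing measured here explains the difference between chloro and chloromethyl.

On these data alone, whether a methyl, a longer chain ending in chlorine or an amine on this carbon would match chloro remains open.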